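The compounds below may be only part of what the source reports. "The series", "measured", "known", "first", "only" and "open" are said of these compounds alone.

Measured compounds:
- compound 1, `COc1ccc(CNc2nc([Se]C)nc3ccccc23)cc1`: 98600 nM
- compound 2, `CCCCC[Se]c1nc([Se]CCCCC)c2cccnc2n1`: 67700 nM
- compound 3, `CSc1ccc(CNc2nc(SC)nc3ncccc23)cc1`: 4370 nM

All three were tested in a functional assay on MCF7 cells (Homo sapiens) for cytotoxicity, read by MTT assay, with a stated time of 72 h; on this read-out higher numbers stand for weaker inhibition of growth and lower numbers for stronger inhibition of growth. Compound 1 has the highest number of the three. Compound 2 lies nearest to it, and the two values are within the scatter of each other, so no order between compound 1 and compound 2 can be read from them. Compound 3 lies furthest from compound 1, and that gap is beyond the scatter: compound 3 inhibits growth more strongly than compound 1.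

Compound 4, `COc1ccc(CNc2nc([SeH])nc3ccccc23)cc1`, has not yet been measured in this assay. It differs from compound 1 in a single place: hydrogen in place of methyl on a selenium. No pair among the measured compounds shows this same change, so the size of the step is not known from the data shown.

The expected step of a 1.6-fold lower number from compound 1 to compound 4 (0.22 log units; within the scatter) is a small one, downward if at all, and not beyond the scatter. The account therefore expects compound 4 to give about 60000 nM, with a range from 15000 nM to 200000 nM, close to compound 1.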

Compound 4, concentration for total growth inhibition: 94000 nM
For compound 4 the middle estimate is 1.6-fold (0.19 log units) below the measured one; the measured number falls inside the stated range.
By their numbers in this assay, from the lowest: compound 3; then compounds 2, 4 and 1 (each within the scatter of the next).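

Among these compounds, putting hydrogen in place of methyl on the selenium gives a 1.0-fold lower number from compound 1 to compound 4 (0.02 log units; within the scatter) in this assay, the first step in this set that can be read at any position. The two compounds cannot be told apart on this read-out, so the methyl group on this selenium can be removed with no change that rises above the scatter, and the core of compound 1 keeps its reading with only a hydrogen at that place. This holds for this one pair alone and sets no rule for other compounds, and nothing shown here accounts for the absence of a change.

The compounds shown leave open whether a group other than methyl or hydrogen on this selenium, such as a longer chain ending in an amine or a carboxylic acid, would move the number beyond the scatter. They also leave open whether hydrogen in place of methyl on a sulfur would be just as silent in compound 3, which stands at 4370 nM.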